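Swapping a sulfonyl group for hydroxymethyl

A few compounds are considered here, and "the series" means these few. Any claim that something is new, unique, unknown or untested is made for them only; others in the source may bear on it.

The three measured compounds share one core and differ only in a single group on the outer aromatic ring. In an assay on CHO cells for displacement of a labelled ligand from prostaglandin D2 receptor 2 (Homo sapiens), read by scintillation counting (on this read-out lower numbers stand for stronger inhibition and higher numbers for weaker inhibition), compound 1 `CN(C)S(=O)(=O)c1ccc(F)c(C#Cc2cc(Cl)ccc2OCC(=O)O)c1` gives 3.1 nM, compound 3 `CCCS(=O)(=O)c1ccc(F)c(C#Cc2cc(Cl)ccc2OCC(=O)O)c1` gives 3.4 nM, and compound 2 `COCc1ccc(F)c(C#Cc2cc(Cl)ccc2OCC(=O)O)c1` gives 72 nM. Compound 3 thus stands second highest of the three numbers, with compound 1 nearest: a 1.1-fold higher number from compound 1 to compound 3 (0.04 log units; within the scatter). Compound 2 is furthest: a 21-fold lower number from compound 2 to compound 3 (1.33 log units; beyond the scatter).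

Compound 4 `O=C(O)COc1ccc(Cl)cc1C#Cc1cc(CO)ccc1F` has not yet been measured in this assay. Relative to compound 3 the change is hydroxymethyl in place of propylsulfonyl on an aromatic carbon.

Going by the values given here, two measured steps bear on this. Exchanging one sulfonyl-bearing group for methoxymethyl gave a 23-fold higher number from compound 1 to compound 2 (1.37 log units; beyond the scatter), and the reverse exchange gave a 21-fold lower number from compound 2 to compound 3 (1.33 log units; beyond the scatter). Hydroxymethyl resembles methoxymethyl in size and in the atoms it carries, so a step of similar size in the weaker direction is expected, a 21-fold higher number from compound 3 to compound 4 (1.31 log units; beyond the scatter). Compound 4 is therefore estimated at 70 nM, with a range from 25 nM to 200 nM.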

Compound 4, inhibition constant: 73 nM
Compound 4: the middle estimate sits 1.0-fold (0.02 log units) below what was measured, and the stated range covers the measured number.
By their numbers in this assay, from the lowest: compounds 1 and 3 (each within the scatter of the next); then compounds 2 and 4 (each within the scatter of the next).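

Removing the methyl from the oxygen changes nothing that can be told apart in this assay (a 1.0-fold higher number from compound 2 to compound 4 (0.01 log units; within the scatter)), so at this position a free hydroxymethyl and a methoxymethyl read alike. The large loss against the sulfonyl-bearing groups therefore does not depend on that methyl, and it appears against both the propylsulfonyl group (a 21-fold higher number from compound 3 to compound 4 (1.33 log units; beyond the scatter)) and the dimethylsulfamoyl group (a 24-fold higher number from compound 1 to compound 4 (1.37 log units; beyond the scatter)). The compounds now fall into two pairs, yet no measurement here gives a reason for the gap between them.

As far as these compounds go, whether a smaller methylsulfonyl group, a nitrile or a primary amide on this aromatic carbon would read like the sulfonyl pair or like the other pair remains open. So does the effect of a longer chain ending in a hydroxyl group.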